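The source may hold more compounds than are shown below. What is called first, only, known or untested is meant among the compounds shown, and "the series" means these compounds.

Compounds measured in an assay on cells for antagonist activity at transient receptor potential cation channel subfamily V member 1 (Homo sapiens), read by FLIPR and calcium flux, with a stated time of 6 min; a higher number here means a weaker inhibitor, a lower number a stronger inhibitor:
compound 1 `CCCN(CCC)c1nc(C(C)(C)C)ccc1CNC(=O)C(C)c1ccc(NS(C)(=O)=O)c(F)c1` gives 2.5 nM;
compound 2 `CC(C(=O)NCc1ccc(C(C)(C)C)nc1N1CCCC1)c1ccc(NS(C)(=O)=O)c(F)c1` gives 1.2 nM;
compound 3 `CCCCSc1nc(C(C)(C)C)ccc1CNC(=O)C(C)c1ccc(NS(C)(=O)=O)c(F)c1` gives 3.2 nM.

Compound 3 carries the highest of the three numbers. Its nearest neighbour is compound 1: a 1.3-fold higher number from compound 1 to compound 3 (0.11 log units; within the scatter), which stays within the scatter. Its furthest is compound 2: a 2.7-fold higher number from compound 2 to compound 3 (0.43 log units; beyond the scatter), a modest step beyond the scatter. Both steps that reach compound 3 change the group on the same aromatic carbon of the shared core, and so far changes at that position have given steps of modest size at most.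

Compound 4 `CCCCCc1nc(C(C)(C)C)ccc1CNC(=O)C(C)c1ccc(NS(C)(=O)=O)c(F)c1` differs from compound 3 at this same carbon: pentyl in place of butylsulfanyl on an aromatic carbon. Among the compounds with values here, no measured pair swaps butylsulfanyl for pentyl, so the measured steps bear on it only indirectly. The step from compound 1 to compound 3, dipropylamino giving way to butylsulfanyl, stayed within the scatter; the step from compound 2 to compound 3 was modest. Exchanging one open chain for another at the same place is therefore expected to move the number little, probably not beyond the scatter, with no clear direction. The expected step is a 1.1-fold higher number from compound 3 to compound 4 (0.04 log units; within the scatter). Compound 4 is estimated at 3.5 nM in this assay, within a range from 1.5 nM to 8 nM.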

Compound 4, inhibition constant: 1.9 nM
Compound 4: middle estimate off by 1.8-fold (0.27 log units), on the high side; the measured number falls inside the stated range.
By their numbers in this assay, from the lowest: compounds 2, 4, 1 and 3 (each within the scatter of the next, the first and the last beyond it).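

In this assay, within the data shown here, pentyl is the first group at this carbon joined to the ring through neither nitrogen nor sulfur, yet the change from butylsulfanyl stays within the scatter (a 1.7-fold lower number from compound 3 to compound 4 (0.23 log units; within the scatter)), so removing the sulfur and the one hydrogen-bond acceptor counted on butylsulfanyl gives no step that can be read as real. The steps from the two amino groups also stay within the scatter (a 1.6-fold higher number from compound 2 to compound 4 (0.20 log units; within the scatter); a 1.3-fold lower number from compound 1 to compound 4 (0.12 log units; within the scatter)), so compound 4 cannot be separated from any earlier compound, even though compound 2 and compound 3 lie a modest step apart, and an open all-carbon chain is thus as compatible with a low-nanomolar number here as pyrrolidin-1-yl, dipropylamino or butylsulfanyl. Nothing at hand explains why these groups read so alike.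

Still open, going by these compounds, is whether a shorter or longer alkyl chain, or a pentyl chain ending in a hydroxyl group or a carboxylic acid, would keep the number in this range at this carbon. Also open, on these data alone, is whether pentyl would hold up as well with trifluoromethyl in place of the tert-butyl group.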